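The compounds below may be only part of what the source reports. "The series", "measured", "known", "first", "only" and "open" are said of these compounds alone.

In a functional assay on T47D cells (Homo sapiens) for cytotoxicity, read by colorimetric assay and MTT assay (on this read-out lower numbers stand for stronger inhibition and higher numbers for weaker inhibition), compound 1 `COc1ccc(-c2cc3c(OC)cc(OC)cc3n(CCCC#N)c2=O)cc1` gives 10000 nM. Compound 2 `COc1ccc(-c2cc3c(OC)cc(OC)cc3n(CCC(=O)OCc3ccccc3)c2=O)cc1` gives 10000 nM, so it stands level with compound 1 and has no better-performing neighbour to be compared with. Among the measured compounds shown here, the one measured step shows no change at the digits printed from compound 1 to compound 2 (within the scatter), a swap of benzyloxycarbonyl for cyanomethyl on a saturated chain carbon. Compound 3 `CCN(CC)C(=O)CCn1c(=O)c(-c2ccc(OC)cc2)cc2c(OC)cc(OC)cc21` keeps the shared core and alters the same end of the chain, with diethylamino in place of benzyloxy on a carbonyl carbon. For the measured compounds named here, this exact swap has not been measured in this small set, so the only guide is the flat step at that chain end, and it is a single example. No step beyond the scatter is therefore expected in this assay. The expected change is no change at the digits printed from compound 2 to compound 3 (within the scatter). Compound 3 is estimated at 10000 nM, with an expected range of 4000 nM to 20000 nM.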

Compound 3, half-maximal inhibitory concentration: 10000 nM
Beside the measured number, compound 3's estimate shows no gap at the digits printed; the range from low to high includes it.
By their numbers in this assay, from the lowest: compounds 1, 2 and 3 (each within the scatter of the next).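

In this assay, putting diethylamino in place of benzyloxy on a carbonyl carbon gives no change at the digits printed from compound 2 to compound 3 (within the scatter), so removing the benzyloxy group's six-membered aromatic ring leaves the number where it was. Diethylcarbamoyl in place of cyanomethyl gives no change at the digits printed from compound 1 to compound 3 (within the scatter), so three different groups at this chain end now read the same, where the earlier compounds offered only two. Nothing available offers a reason for this flat result.

The compounds shown leave open whether any group at this chain end can move the number at all, such as a carboxylic acid or an amine. They also leave open whether a longer chain between the aromatic nitrogen and the carbonyl carbon would give a lower number in this assay.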